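Compound 2 to compound 4: replacing the methyl

This account rests on a few compounds, and the source may have more. Where it says the series, first, only, none or still open, it means among the compounds named here.

In a functional assay on HCC827 cells (Homo sapiens) for cytotoxicity, read by MTT assay, with a stated time of 72 h (a lower number here means a stronger inhibitor, a higher number a weaker inhibitor), compound 2 (`Cc1cccc(Nc2nc3cnc(Nc4ccc(N5CCN(C)CC5)cc4)nc3n2C2CCCC2)c1`) gives < 0.01 nM, which is a limit of the assay and not a number. Compound 1 (`CN1CCN(c2ccc(Nc3ncc4nc(Nc5cccc([N+](=O)[O-])c5)n(C5CCCC5)c4n3)cc2)CC1`) gives < 0.01 nM, also a limit. Compound 3 (`CN1CCN(c2ccc(Nc3ncc4nc(Nc5cc(Cl)ccc5Cl)n(C5CCCC5)c4n3)cc2)CC1`) gives 0.01 nM.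

Compound 4 (`CN1CCN(c2ccc(Nc3ncc4nc(Nc5cccc(C(=O)Nc6ccc(Cl)cc6)c5)n(C5CCCC5)c4n3)cc2)CC1`) differs from compound 2 by (4-chlorophenyl)carbamoyl in place of methyl on an aromatic carbon. Among the compounds with values here, the change is (4-chlorophenyl)carbamoyl in place of methyl on an aromatic carbon, and this group has no counterpart among the measured compounds.

The relevant steps are a step that the two limits leave unreadable from compound 1 to compound 2, a number no lower from compound 2 to compound 3 (the limit leaves the size open) and a number no lower from compound 1 to compound 3 (the limit leaves the size open). None has a readable size because of the limit of < 0.01 nM in this assay, at which 2 of the 3 values shown sit. They therefore set no firm size for the new change. Since compound 2 gives only a limit, any readable change in this assay is expected to be upward, and modest rather than large.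

The expected step is an at least 5.0-fold higher number from compound 2 to compound 4 (0.69 log units; beyond the scatter), and this estimate is loose. For compound 4 the estimated value is 0.05 nM, with an expected range of 0.005 nM to 1 nM.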

Compound 4, half-maximal inhibitory concentration: 2900 nM
For compound 4 the middle estimate is 58000-fold (4.76 log units) below the measured one; the whole stated range lies below it.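

Placing (4-chlorophenyl)carbamoyl on this aromatic carbon, meta to a large group, gives an at least 290000-fold higher number from compound 2 to compound 4 (5.46 log units; beyond the scatter) in this assay, and against nitro at the same place it gives an at least 290000-fold higher number from compound 1 to compound 4 (5.46 log units; beyond the scatter). Within the data shown here, these are the first readable steps at this position, and they show that it does not accept every group, which methyl and nitro alone could not show. The earlier steps among compound 1, compound 2 and compound 3 cannot be read because of a limit: the limit of < 0.01 nM in this assay, at which 2 of the 4 values shown sit.

The entering group brings in the carbonyl, the amide hydrogen and the chlorinated aromatic ring together, and the compounds shown do not separate their shares in the step. A small group at this carbon, such as an amine or a carboxylic acid, would help show where between methyl and (4-chlorophenyl)carbamoyl the number begins to rise.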